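The source may hold more compounds than are shown below. What is called first, only, known or untested is meant among the compounds shown, and "the series" means these compounds.

Measured so far:
- compound 1 `CCN1CCN(c2cc(C(F)(F)F)nc(SCc3ccc(C(F)(F)F)cc3)n2)CC1`: 22000 nM
- compound 2 `Cc1csc(Sc2cc(C(F)(F)F)nc(SCc3ccc(C(F)(F)F)cc3)n2)n1`: 14500 nM

Both values come from a functional assay on MCF7 cells (Homo sapiens) for inhibition, read by MTT assay, with a stated time of 72 h; a higher number here means a weaker inhibitor, a lower number a stronger inhibitor. Within the data shown here, compound 2 stands level with compound 1 within the scatter, with the only measured step being a 1.5-fold lower number from compound 1 to compound 2 (0.18 log units; within the scatter).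

Next is compound 3 `FC(F)(F)c1ccc(CSc2nc(Sc3ncccn3)cc(C(F)(F)F)n2)cc1`. The change is pyrimidin-2-yl in place of 4-methyl-1,3-thiazol-2-yl on a sulfur, which reads as (4-methyl-1,3-thiazol-2-yl)sulfanyl to (pyrimidin-2-yl)sulfanyl. The link through sulfur and the rest of the molecule stay the same.

Among the measured compounds shown here, no measured step makes this exact exchange. The nearest evidence is a 1.5-fold lower number from compound 1 to compound 2 (0.18 log units; within the scatter), which replaced 4-ethylpiperazin-1-yl at the same aromatic carbon and stayed within the scatter. On that single step, no change beyond the scatter is expected in this assay, and no direction is favoured. The expected step is a 1.0-fold higher number from compound 2 to compound 3 (0.01 log units; within the scatter). For compound 3 the estimated value is 15000 nM, with an expected range of 7000 nM to 30000 nM.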

Compound 3, half-maximal inhibitory concentration: > 50000 nM
Compound 3: a limit, no number; the forecaster's own chance of this, stated with the estimate: 10%; at least 3.3-fold (0.52 log units) between middle value and limit.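

Compound 3 stands at a limit of the assay, not at a number, in this assay: the limit of > 50000 nM in this assay, at which 1 of the 3 values shown sits.

The earlier step left this position looking insensitive, but the group on the sulfur does matter: pyrimidin-2-yl in place of 4-methyl-1,3-thiazol-2-yl gives an at least 3.4-fold higher number from compound 2 to compound 3 (0.53 log units; beyond the scatter), even though the two groups match in heavy atoms and hydrogen-bond acceptors. On the same aromatic carbon, (pyrimidin-2-yl)sulfanyl in place of 4-ethylpiperazin-1-yl gives an at least 2.2-fold higher number from compound 1 to compound 3 (0.35 log units; beyond the scatter), so the sulfur link alone does not set the result.

This exchange alters the ring size, the ring hetero atoms and the methyl group together, so the compounds shown do not separate these changes. As far as these compounds go, it remains open whether an unsubstituted 1,3-thiazol-2-yl or a plain phenyl on the same sulfur would sit with compound 2 or with compound 3.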